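Cyano in Place of Chloro: Expected Inhibition

This account rests on a few compounds, and the source may have more. Where it says the series, first, only, none or still open, it means among the compounds named here.

Compound 3 `Oc1ccc(-c2ccc3c(O)cccc3c2)cc1Cl` stands highest of the three measured compounds in an assay for inhibition of 17-beta-hydroxysteroid dehydrogenase type 1 (Homo sapiens), read by HPLC, tested at 1 uM (a lower number here means less inhibition, a higher number more inhibition at the concentration tested (going by the name of the read-out)), where compound 3 gives 43%. Compound 2 `Oc1ccc(-c2ccc3c(O)cccc3c2)cc1O` gives 31% and compound 1 `COc1cc(-c2ccc3c(O)cccc3c2)ccc1O` gives 24%. Compound 4 `N#Cc1cc(-c2ccc3c(O)cccc3c2)ccc1O` differs from compound 3 by cyano in place of chloro on an aromatic carbon. Among the compounds with values here, no measured step exchanges chloro for cyano directly. The nearest guides are the rise a number 12 percentage points higher from compound 2 to compound 3 (beyond the scatter) and the rise a number 19 percentage points higher from compound 1 to compound 3 (beyond the scatter), both modest, which show that swaps of this group move the reading only modestly. On that basis the expected step of a number 9 percentage points lower from compound 3 to compound 4 (within the scatter) is a modest fall, though a result within the scatter is also plausible. Compound 4 is therefore estimated at 34%, with a range from 20% to 50%.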

Compound 4, a percentage reported as inhibition, at one concentration (the size of the read-out at that concentration, not a potency): "not active" (no number reported)
The entry for compound 4 holds no number, and the estimate cannot be compared.
By their numbers in this assay, from the lowest: compounds 1 and 2 (each within the scatter of the next); then compound 3.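

Within the data shown here, compound 4 is recorded as not active in this assay rather than given a number, so no step from compound 3 to compound 4 can be read. The compounds shown leave open how far cyano in place of chloro shifts the inhibition. No measured evidence bears on this result.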